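Aryl swap on the amide-type nitrogen: working notes

A few compounds are considered here, and "the series" means these few. Any claim that something is new, unique, unknown or untested is made for them only; others in the source may bear on it.

For the measured compounds named here, compound 1 `N#Cc1ccc(NC(=S)N/N=C/c2ccc3ccccc3n2)cc1` is the only member of the series with a numerical result so far: in a functional assay on SGC-7901 cells (Homo sapiens) for antiproliferative activity, read by sulforhodamine B assay, with a stated time of 72 h (a lower number here means a stronger inhibitor, a higher number a weaker inhibitor), compound 1 gives 23700 nM. Compound 2 `NC(=S)N/N=C/c1ccc2cccnc2n1` has no number in this assay; for compound 2 the result is a limit, > 100000 nM, so its true value is not known. Going by the values given here, compound 1 therefore stands alone as the single measured point, the other entry being the limit (the limit of > 100000 nM in this assay, at which 1 of the 2 values shown sits), and no step between two measured compounds is available to calibrate the next change.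

Compound 3 `Fc1cccc(NC(=S)N/N=C/c2ccc3ccccc3n2)c1` is still to be measured in this assay. It differs from compound 1 in a single place, (3-fluorophenyl in place of 4-cyanophenyl on an amide-type nitrogen). Both groups are single six-membered aromatic rings of carbon on the same amide-type nitrogen, so the replacement keeps the overall shape of compound 1 and alters only the substituent on that ring.

Among the compounds with values here, with no measured step to lean on, the expectation for the change from compound 1 to compound 3 is a step of a 1.3-fold higher number from compound 1 to compound 3 (0.10 log units; within the scatter), which is within the usual scatter of repeated measurements. For compound 3 the estimated result in this assay is 30000 nM, with a likely range from 8000 nM to 100000 nM.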

Compound 3, half-maximal inhibitory concentration: 79900 nM
For compound 3 the middle estimate is 2.7-fold (0.43 log units) below the measured one, and the stated range covers the measured number.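

For the compounds shown here, this is the first step that can be read between two measured compounds: in this assay, the aryl swap on the amide-type nitrogen gives a 3.4-fold higher number from compound 1 to compound 3 (0.53 log units; beyond the scatter). The aryl group at this position therefore affects the read-out, and 4-cyanophenyl is the better of the two groups tested here, although both compounds still return a number rather than a limit. Nothing measured on either group accounts for the step, and 3-fluorophenyl and 4-cyanophenyl differ in both substituent and ring position, so the contribution of each cannot be separated from this single pair.

Open, as far as these compounds go, is whether 3-cyanophenyl or 4-fluorophenyl would separate the substituent from its ring position, and whether an amine or a carboxylic acid on the same phenyl ring would move the number in either direction from that of compound 1. Compound 2 provides a limit and not a number, so it cannot calibrate any further step: the limit of > 100000 nM in this assay, at which 1 of the 3 values shown sits.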